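Swapping Methoxy for Hydroxy on a Shared Core

This account rests on a few compounds, and the source may have more. Where it says the series, first, only, none or still open, it means among the compounds named here.

Of the compounds shown here, three of one shared core have been measured in a functional assay on MCF7 cells (Homo sapiens) for inhibition, read by sulforhodamine B assay, with a stated time of 48 h; on this read-out lower numbers stand for stronger inhibition of growth and higher numbers for weaker inhibition of growth. Compound 1 `O=C(Nc1cccc(-n2cc(-c3ccncc3)c(-c3ccc(Cl)c(O)c3)n2)c1)Nc1cccc(C(F)(F)F)c1` gives 1340 nM, compound 2 `COc1cc(-c2nn(-c3cccc(NC(=O)c4cccc(C(F)(F)F)c4)c3)cc2-c2ccncc2)ccc1Cl` gives 1430 nM, and compound 3 `COc1cc(-c2nn(-c3cccc(NC(=O)Nc4ccc(Cl)c(Cl)c4)c3)cc2-c2ccncc2)ccc1Cl` gives 945 nM. Compound 3 carries the lowest of the three numbers, yet it sits within the scatter of both others, so no order among them can be drawn. Within the data shown here, the only single-point step, a 1.5-fold lower number from compound 2 to compound 3 (0.18 log units; within the scatter), concerns the group on the carbonyl carbon and leaves the aromatic oxygen untouched. Compound 4 `O=C(Nc1cccc(-n2cc(-c3ccncc3)c(-c3ccc(Cl)c(O)c3)n2)c1)Nc1ccc(Cl)c(Cl)c1` differs from compound 3 by hydrogen in place of methyl on an oxygen on an aromatic ring. Among the measured compounds shown here, no measured pair isolates this change, since compound 1 and compound 2 differ in two places. Compound 4 is therefore expected to show a 1.1-fold higher number from compound 3 to compound 4 (0.02 log units; within the scatter), nothing beyond the scatter. Compound 4 is estimated at 1000 nM, between 450 nM and 2300 nM.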

Compound 4, concentration for 50% growth inhibition: 1060 nM
Compound 4: middle estimate off by 1.1-fold (0.03 log units), on the low side; the measured number falls inside the stated range.
By their numbers in this assay, from the lowest: compounds 3, 4, 1 and 2 (each within the scatter of the next).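

In this assay the methoxy to hydroxy change now has a measured pair of its own, and it gives a 1.1-fold higher number from compound 3 to compound 4 (0.05 log units; within the scatter) on the 4-chloro-3-methoxyphenyl group. With hydroxy in place, the group on the amide-type nitrogen also has a direct comparison, a 1.3-fold lower number from compound 1 to compound 4 (0.10 log units; within the scatter) for 3,4-dichlorophenyl in place of 3-(trifluoromethyl)phenyl. No evidence is available that bears on these results. As far as these compounds go, what an ethoxy group or an amine would give in place of the methoxy stays open, as does the outcome of the methoxy to hydroxy change with other groups on the amide-type nitrogen.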